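A few compounds are considered here, and "the series" means these few. Any claim that something is new, unique, unknown or untested is made for them only; others in the source may bear on it.

Measured in a functional assay on HeLa S3 cells (Homo sapiens) for antiproliferative activity, read by XTT assay, with a stated time of 72 h; on this read-out higher numbers stand for weaker inhibition and lower numbers for stronger inhibition:

- Compound 1 `COc1ncnc2c1c(-c1cc3ccccc3o1)cn2[C@@H]1O[C@H](CO)[C@@H](O)[C@H]1O`: 9240 nM
- Compound 2 `CSc1ncnc2c1c(-c1cccs1)cn2[C@@H]1O[C@H](CO)[C@@H](O)[C@H]1O`: 1960 nM
- Compound 3 `CNc1ncnc2c1c(-c1ccco1)cn2[C@@H]1O[C@H](CO)[C@@H](O)[C@H]1O`: 5000 nM

These three compounds differ from one another in more than one place, so no single change can be read from them directly. In this assay, compound 3 at 5000 nM lies within the usual scatter of compound 1 at 9240 nM and cannot be told apart from it. Compound 2 at 1960 nM gives a lower number than compound 3, and that gap lies beyond the scatter.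

Compound 4 `CNc1ncnc2c1c(-c1ccccc1)cn2[C@@H]1O[C@H](CO)[C@@H](O)[C@H]1O` departs from compound 3 in one place only: phenyl in place of furan-2-yl on an aromatic carbon. This puts phenyl in place of furan-2-yl on an aromatic carbon. Among the measured compounds shown here, the data hold no measured example of this exchange, so any expectation for it is tentative. Compound 3 at 5000 nM and compound 1 at 9240 nM mark the region where the expectation is anchored. A small move toward weaker inhibition seems most likely, within the scatter or only just past it. The expected change is a 1.6-fold higher number from compound 3 to compound 4 (0.20 log units; within the scatter). For compound 4 the estimated value is 8000 nM, with an expected range from 2500 nM to 25000 nM.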

Compound 4, half-maximal inhibitory concentration: > 20000 nM
Compound 4 gave a limit, no number (the forecaster's own chance of this, stated with the estimate: 25%); at least 2.5-fold (0.39 log units) between middle value and limit.
By their numbers in this assay, from the lowest: compound 2; then compounds 3 and 1 (each within the scatter of the next). At a limit, above all of these: compound 4.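

In this assay compound 4 gives > 20000 nM, which is a limit of the assay and not a number. Phenyl in place of furan-2-yl on this aromatic carbon brings an at least 4.0-fold higher number from compound 3 to compound 4 (0.60 log units; beyond the scatter), the first change in one place only among the compounds shown, and it lies beyond the scatter, so this position does not treat these two aromatic rings alike. The step can be stated only as a minimum, and how far compound 4 actually lies from compound 3 stays unknown: the limit of > 20000 nM in this assay, at which 1 of the 4 values shown sits.

Phenyl differs from furan-2-yl both in ring size and in the lack of a ring oxygen, so the compounds shown cannot tell which of the two differences goes with the weaker inhibition. On these data alone, a pyridin-2-yl group on the same carbon, a six-membered aromatic ring that carries a nitrogen, or a methyl group in place of any ring there, would be further exchanges on which these compounds are silent, and the effect of the ring at this position on the other groups of the core also remains open.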